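Furan in place of fluorophenyl on a weakly active amide pair

The source may report more compounds than this note shows. Statements on the series, on what has been measured and on what is new or still open speak of the compounds shown alone.

Compound 1 `CCNc1cc(C)c2cc(NC(=O)c3ccc(Cl)c(Cl)c3)ccc2n1`: 28200 nM
Compound 2 `CCN1CCN(c2cc(C)c3cc(NC(=O)c4ccccc4F)ccc3n2)CC1`: 38100 nM

In a functional assay on SK-BR-3 cells (Homo sapiens) for antiproliferative activity, read by MTT assay, with a stated time of 72 h (a higher number here means a weaker inhibitor, a lower number a stronger inhibitor), compound 2 gives 38100 nM and compound 1 gives 28200 nM; the two numbers lie within the usual scatter of each other, so neither compound can be set apart. Compound 3 `CCN1CCN(c2cc(C)c3cc(NC(=O)c4ccco4)ccc3n2)CC1` differs from compound 2 in one place: furan-2-yl in place of 2-fluorophenyl on a carbonyl carbon. Going by the values given here, no measured pair shows what this change does. Compound 3 is therefore expected to stay close to compound 2, with a step of a 1.0-fold higher number from compound 2 to compound 3 (0.02 log units; within the scatter) that is not beyond the scatter. The estimate for compound 3 is 40000 nM, from 15000 nM to 100000 nM.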

Compound 3, half-maximal inhibitory concentration: 37500 nM
For compound 3 the middle estimate is 1.1-fold (0.03 log units) above the measured one; low and high end bracket the measured number.
By their numbers in this assay, from the lowest: compounds 1, 3 and 2 (each within the scatter of the next).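

In this assay, going by these compounds alone, furan-2-yl in place of 2-fluorophenyl on the carbonyl carbon gives a 1.0-fold lower number from compound 2 to compound 3 (0.01 log units; within the scatter) and so provides the first readable step at this position. A five-membered aromatic ring with one oxygen and a six-membered aromatic ring of carbon only cannot be told apart here, and both compounds stay in the same weak range. Nothing measured bears on why this is so. On these data alone, whether a cyclohexyl ring or a carboxylic acid on that carbonyl carbon would move the number beyond the scatter stays open. Compound 1 differs from compound 2 and compound 3 in more than one place, so it cannot settle this.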